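The compounds below may be only part of what the source reports. "The series", "measured", "known", "first", "only" and "open" are said of these compounds alone.

Compound 1 `Cn1c(N)c(-c2nc3ccccc3[nH]2)c2nc(C#N)c(C#N)nc21` is the starting point. In a functional assay on HeLa cells (Homo sapiens) for antiproliferative activity, read by MTT assay, with a stated time of 48 h (on this read-out higher numbers stand for weaker inhibition and lower numbers for stronger inhibition), compound 1 gives > 50000 nM, which is a limit of the assay rather than a measured number. A related compound 2 `CCCCn1c(N)c(-c2nc3ccccc3[nH]2)c2nc(C#N)c(C#N)nc21` gives > 50000 nM, again a limit and not a number. The step that the two limits leave unreadable from compound 1 to compound 2 therefore cannot be read. Going by the values given here, both values sit at the limit of > 50000 nM in this assay, at which 2 of the 2 values shown sit, so no measured step shows how a chain on that nitrogen changes potency in this assay. Compound 3 `N#Cc1nc2c(-c3nc4ccccc4[nH]3)c(N)n(CCCNc3ccccc3)c2nc1C#N` differs from compound 1 by 2-anilinoethyl in place of hydrogen on a saturated chain carbon bound to an aromatic nitrogen. With only limits to go on, the expected step of a number no higher from compound 1 to compound 3 (the limit leaves the size open) is simply a return of the same limit, and no size can be stated for it. For compound 3 the estimate is 50000 nM, with a range from 20000 nM to 120000 nM, and it is expected that the assay again reports only a limit.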

Compound 3, half-maximal inhibitory concentration: 26300 nM
Estimate against measurement, compound 3: 1.9-fold (0.28 log units) above; the measured number falls inside the stated range.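

In this assay compound 3 is the first of the three to give a measured number, 26300 nM, and it is the only one shown whose chain on the aromatic nitrogen carries an anilino group. Replacing hydrogen with 2-anilinoethyl gives an at least 1.9-fold lower number from compound 1 to compound 3 (0.27 log units; that floor lies within the scatter), and replacing methyl with anilino on the chain gives an at least 1.9-fold lower number from compound 2 to compound 3 (0.27 log units; that floor lies within the scatter). Each step is a floor and not a full size, as one end of each is a limit of the assay rather than a number: the limit of > 50000 nM in this assay, at which 2 of the 3 values shown sit.

As far as these compounds go, the true size of either step stays open, as does how much of it belongs to the anilino group and how much to the chain itself. A 3-phenylpropyl chain, or a chain carrying a carboxylic acid, would test these questions at this position, but neither is among the compounds shown.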